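Swapping naphthalen-2-yl for 3-phenoxypropyl on a carbonyl carbon

This account rests on a few compounds, and the source may have more. Where it says the series, first, only, none or still open, it means among the compounds named here.

Of the compounds shown here, three built on a shared core have been tested so far. In a functional assay on HCT-116 cells (Homo sapiens) for inhibition, read by sulforhodamine B assay, with a stated time of 72 h (a higher number here means a weaker inhibitor of growth, a lower number a stronger inhibitor of growth), compound 1 (`O=C(NO)c1cnc(N2C[C@@H]3CN(S(=O)(=O)c4ccc5ccccc5c4)C[C@@H]3C2)nc1`) gives 740 nM and compound 2 (`O=C(NO)c1cnc(N2C[C@@H]3CN(S(=O)(=O)c4ccc(OC(F)(F)F)cc4)C[C@@H]3C2)nc1`) gives 530 nM while compound 3 (`O=C(NO)c1cnc(N2C[C@H]3CN(C(=O)c4ccc5ccccc5c4)C[C@H]3C2)nc1`) gives 590 nM on the same read-out. These three values lie within the usual scatter of one another, so compound 3 cannot be ranked against the other two.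

Compound 4 (`O=C(NO)c1cnc(N2C[C@H]3CN(C(=O)CCCOc4ccccc4)C[C@H]3C2)nc1`) has not yet been measured. Going by the values given here, it carries 3-phenoxypropyl in place of naphthalen-2-yl on a carbonyl carbon as its single change from compound 3.

Among the compounds with values here, no two measured compounds differ in one place only, so no direct guide to this swap exists. Compound 1 at 740 nM and compound 3 at 590 nM carry different groups yet stay within the scatter of each other, so no change beyond the scatter is expected in this assay here. The expected step is a 1.0-fold higher number from compound 3 to compound 4 (0.01 log units; within the scatter) and it should stay within the scatter. For compound 4 the estimated value is 600 nM with an expected range from 200 nM to 1800 nM until the measurement arrives.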

Compound 4, concentration for 50% growth inhibition: 1800 nM
Estimate against measurement, compound 4: 3.0-fold (0.48 log units) below; the measured number falls inside the stated range.
By their numbers in this assay, from the lowest: compounds 2, 3 and 1 (each within the scatter of the next); then compound 4.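

Swapping naphthalen-2-yl for 3-phenoxypropyl on a carbonyl carbon gives a 3.1-fold higher number from compound 3 to compound 4 (0.48 log units; beyond the scatter) in this assay, the only step shown between two compounds that differ in one place. Growth inhibition therefore does respond to the group at this position, and the two groups' equal heavy-atom count does not keep the values together. The swap replaces two aromatic rings with one and also brings in a chain and an oxygen, and nothing available explains why the number rises.

As far as these compounds go, whether the higher number follows the loss of the second ring or the arrival of the chain and its oxygen remains open. A plain phenyl on the same carbonyl carbon, or a 4-phenylbutyl group with carbon in place of the oxygen, would help to separate these changes.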